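From 3-bromo-4-methylphenyl to pentyl: working notes

This account rests on a few compounds, and the source may have more. Where it says the series, first, only, none or still open, it means among the compounds named here.

Within the data shown here, in a functional assay on HepG2 cells (Homo sapiens) for antiproliferative activity, read by MTT assay (on this read-out higher numbers stand for weaker inhibition and lower numbers for stronger inhibition), only two compounds have been measured so far. Compound 1 `CC1(C)CCc2c(ccc(C(=O)/C=C/c3ccc(OCc4cn(-c5ccc(Br)cc5)nn4)cc3)c2O)O1` gives 136000 nM, and compound 2 `Cc1ccc(-n2cc(COc3ccc(/C=C/C(=O)c4ccc5c(c4O)CCC(C)(C)O5)cc3)nn2)cc1Br` gives 110000 nM. These two values lie within the scatter of each other, so compound 2 cannot be separated from compound 1 on these numbers.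

The next compound is compound 3 `CCCCCn1cc(COc2ccc(/C=C/C(=O)c3ccc4c(c3O)CCC(C)(C)O4)cc2)nn1`, which carries pentyl in place of 3-bromo-4-methylphenyl on an aromatic nitrogen of a five-membered aromatic ring with 3 nitrogen: pentyl in place of 3-bromo-4-methylphenyl on an aromatic nitrogen.

Among the measured compounds shown here, the only measured step that bears on this change is a 1.2-fold lower number from compound 1 to compound 2 (0.09 log units; within the scatter), with 3-bromo-4-methylphenyl in place of 4-bromophenyl. That step stays within the scatter, but it retains an aromatic ring on the nitrogen. For the measured compounds named here, no measured step removes that ring, so the direction of any shift is unsupported by the data. In this assay, no shift beyond the scatter is therefore expected, and the estimated step is a 1.2-fold lower number from compound 2 to compound 3 (0.09 log units; within the scatter). Compound 3 is expected at 90000 nM, with an estimated range of 30000 nM to 220000 nM.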

Compound 3, half-maximal inhibitory concentration: 9820 nM
Beside the measured number, compound 3's estimate is 9.2-fold (0.96 log units) above it, and the stated range ends above it.
By their numbers in this assay, from the lowest: compound 3; then compounds 2 and 1 (each within the scatter of the next).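

In this assay, pentyl in place of 3-bromo-4-methylphenyl on the aromatic nitrogen gives an 11-fold lower number from compound 2 to compound 3 (1.05 log units; beyond the scatter), and pentyl in place of 4-bromophenyl at the same place gives a 14-fold lower number from compound 1 to compound 3 (1.14 log units; beyond the scatter). The earlier exchange of one substituted phenyl group for another, a 1.2-fold lower number from compound 1 to compound 2 (0.09 log units; within the scatter), left this position looking flat, whereas these two steps show that the read-out does respond to the group on this nitrogen, and compound 3 stands beyond the scatter from both compounds that carry an aromatic ring there. The change removes the six-membered aromatic ring and the bromine and alters the heavy-atom count all at once, so the steps cannot assign the drop to any one of these, and no measurement at hand bears on the reason for it.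

The compounds shown leave open whether the ring's removal or the chain itself governs the step, a question that a cyclohexyl group or an unsubstituted benzyl group on the same nitrogen would bear on. They also leave open how the number follows chain length, as propyl or a longer chain such as octyl would show, and whether a chain ending in an amine or a carboxylic acid would fit the same trend.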